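From Methoxy to Fluoro on the Pendant Phenyl

This account rests on a few compounds, and the source may have more. Where it says the series, first, only, none or still open, it means among the compounds named here.

The series begins with compound 1 `Cc1cc(Cl)nnc1N1CCN(c2ncccn2)CC1`. In a functional assay on BV-2 cells (Mus musculus) for inhibition, read by ELISA, with a stated time of 16 h (a lower number here means a stronger inhibitor, a higher number a weaker inhibitor), compound 1 gives > 100000 nM, which is a limit of the assay and not a number. Compound 2 `Cc1cc(C)c(N2CCN(c3ncccn3)CC2)nn1` carries a methyl in place of the chloro; in this assay compound 2 gives > 100000 nM, again a limit. The step between them is a step that the two limits leave unreadable from compound 1 to compound 2. Within the data shown here, compound 3 `COc1cccc(-c2cc(C)c(N3CCN(c4ncccn4)CC3)nn2)c1` carries a 3-methoxyphenyl in that place, and in this assay compound 3 gives 2600 nM, the only actual number among the three, the other two sitting at the limit of > 100000 nM in this assay, at which 2 of the 3 values shown sit. The step of an at least 38-fold lower number from compound 1 to compound 3 (1.58 log units; beyond the scatter) and the step of an at least 38-fold lower number from compound 2 to compound 3 (1.58 log units; beyond the scatter) are both large.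

The next compound, compound 4 `Cc1cc(-c2cccc(F)c2)nnc1N1CCN(c2ncccn2)CC1`, differs from compound 3 in one place: fluoro in place of methoxy on an aromatic carbon. None of the measured steps exchanges one substituent on that phenyl for another; the two large steps only show that, among these compounds, the 3-methoxyphenyl is what brings a readable number. The author therefore expects no step beyond the scatter, a 1.2-fold higher number from compound 3 to compound 4 (0.06 log units; within the scatter), in this assay. Compound 4 is expected to give about 3000 nM in this assay, within 800 nM to 12000 nM.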

Compound 4, half-maximal inhibitory concentration: 33500 nM
For compound 4 the middle estimate is 11-fold (1.05 log units) below the measured one, outside the stated range (above it).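

The change of one group on the pendant phenyl is enough to move the number in this assay: a 13-fold higher number from compound 3 to compound 4 (1.11 log units; beyond the scatter). Earlier, the large steps showed only that the 3-methoxyphenyl brought a readable value in place of chloro or methyl, whereas here the group on an aromatic carbon, meta to a large group, proves to matter in its own right, and a phenyl with fluoro there does not reach the 2600 nM of compound 3. The 3-fluorophenyl still keeps some of the gain, with an at least 2.9-fold lower number from compound 2 to compound 4 (0.47 log units; beyond the scatter) and an at least 2.9-fold lower number from compound 1 to compound 4 (0.47 log units; beyond the scatter), yet these two steps are only bounds because compound 1 and compound 2 each sit at a limit of the assay and not at a number: the limit of > 100000 nM in this assay, at which 2 of the 4 values shown sit.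

The compounds shown leave open whether the methoxy works through its oxygen or through its methyl, and a hydroxy or an ethoxy on the same carbon would begin to separate the two. They also leave open where a plain phenyl, or one carrying a dimethylamino group or a carboxylic acid in that place, would fall relative to compound 3 and compound 4.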